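Replacing a chlorothiazole with a methylphenyl on the sulfonyl

This account rests on a few compounds, and the source may have more. Where it says the series, first, only, none or still open, it means among the compounds named here.

The three measured compounds share a core and differ only in the aromatic group on the sulfonyl sulfur. Compound 3 `CC1CCN(C2CCN(S(=O)(=O)c3cnc(Cl)s3)CC2)CC1` gives 1800 nM in a functional assay on DLD-1 cells (Homo sapiens) for antiproliferative activity, read by CellTiter-Glo, with a stated time of 72 h (a lower number here means a stronger inhibitor, a higher number a weaker inhibitor), the highest number of the three. Compound 1 `CC1CCN(C2CCN(S(=O)(=O)c3cccc(Br)c3)CC2)CC1` gives 3.2 nM and compound 2 `Cc1ccc(-c2cccc(S(=O)(=O)N3CCC(N4CCC(C)CC4)CC3)c2)cc1` gives 11 nM. Compound 4 `Cc1cccc(S(=O)(=O)N2CCC(N3CCC(C)CC3)CC2)c1` carries the change (3-methylphenyl in place of 2-chloro-1,3-thiazol-5-yl on a sulfonyl sulfur). Among the measured compounds shown here, the closest precedent is a 560-fold higher number from compound 1 to compound 3 (2.75 log units; beyond the scatter), which ran in the opposite direction. The step of a 3.4-fold higher number from compound 1 to compound 2 (0.54 log units; beyond the scatter) shows that a substituent on that phenyl ring changes the number only modestly. A large drop is therefore expected, a 300-fold lower number from compound 3 to compound 4 (2.48 log units; beyond the scatter). Compound 4 is estimated at 6 nM, within a range from 2 nM to 25 nM.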

Compound 4, half-maximal inhibitory concentration: 25 nM
For compound 4 the middle estimate is 4.2-fold (0.62 log units) below the measured one, within the range that was stated.
By their numbers in this assay, from the lowest: compound 1; then compound 2; then compound 4; then compound 3.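

Changing the aromatic group on the sulfonyl sulfur from 2-chloro-1,3-thiazol-5-yl to 3-methylphenyl gives a 72-fold lower number from compound 3 to compound 4 (1.86 log units; beyond the scatter) and so recovers most of the gap seen with the bromo compound. Methyl is nevertheless not equal to the earlier phenyl substituents, with a 7.8-fold higher number from compound 1 to compound 4 (0.89 log units; beyond the scatter) when it replaces bromo and a 2.3-fold higher number from compound 2 to compound 4 (0.36 log units; beyond the scatter) when it replaces 4-methylphenyl. Nothing available explains the size of these steps. On these data alone, whether an amine or a carboxylic acid on the phenyl ring would keep the number low remains open, as does the effect of a pyridine ring in place of the phenyl.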